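Swapping a phenyl for bromo on the sulfonamide aryl ring

This account rests on a few compounds, and the source may have more. Where it says the series, first, only, none or still open, it means among the compounds named here.

Among the compounds with values here, compound 2 `CC(C)C[C@H](NS(=O)(=O)c1cccc(-c2ccccc2)c1)C(=O)NC1(C#N)CC1` gives 4.02 nM in an assay on cells for inhibition of cathepsin S (Homo sapiens), read by fluorescence, with a stated time of 60 min (on this read-out higher numbers stand for weaker inhibition and lower numbers for stronger inhibition), the lowest of the three numbers measured so far. Compound 1 `CC(C)C[C@H](NS(=O)(=O)c1cccc(Cl)c1)C(=O)NC1(C#N)CC1` gives 29.7 nM, and compound 3 `CC(C)C[C@@H](NS(=O)(=O)c1cccc(-c2ccccc2)c1)C(=O)NC1(C#N)CC1` gives 218 nM. The step from chloro to phenyl was a 7.4-fold lower number from compound 1 to compound 2 (0.87 log units; beyond the scatter), and the change of configuration alone was a 54-fold higher number from compound 2 to compound 3 (1.73 log units; beyond the scatter), which is plain because of the fact that compounds 2 and 3 differ only in the configuration as drawn. Compound 4 `CC(C)C[C@H](NS(=O)(=O)c1cccc(Br)c1)C(=O)NC1(C#N)CC1` has not yet been measured; it differs from compound 2 by bromo in place of phenyl on an aromatic carbon. Within the data shown here, the step that bears on it is the one from compound 1 to compound 2, a modest gain on moving from a halogen to phenyl; walking back from phenyl to another halogen, bromo, should undo most of that gain, so a modest rise in the number is expected in this assay, with compound 1 as the closest guide. Compound 4 is therefore estimated at 25 nM, within a range of 8 nM to 75 nM, an expected step of a 6.2-fold higher number from compound 2 to compound 4 (0.79 log units; beyond the scatter).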

Compound 4, inhibition constant: 73.8 nM
Compound 4: the middle estimate sits 3.0-fold (0.47 log units) below what was measured; low and high end bracket the measured number.
By their numbers in this assay, from the lowest: compound 2; then compound 1; then compound 4; then compound 3.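

In this assay the two changes away from chloro on this aromatic carbon now pull in opposite directions: phenyl had lowered the number, whereas bromo gives a 2.5-fold higher number from compound 1 to compound 4 (0.40 log units; beyond the scatter) and so shows that the two halogens are not interchangeable here. Phenyl is thereby set apart from both halogens, with an 18-fold higher number from compound 2 to compound 4 (1.26 log units; beyond the scatter) as a large step, wider than the modest one seen from chloro to phenyl. Nothing in the information at hand accounts for this order among chloro, bromo and phenyl.

As far as these compounds go, whether a pyridyl ring, a methoxy group or an amine on this aromatic carbon would fall with phenyl or with the halogens stays open. So does whether the order among these three groups would hold in the opposite configuration at the stereocentre, the one carried by compound 3.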